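A Methyl Moved Around the Phenyl Ring

This account rests on a few compounds, and the source may have more. Where it says the series, first, only, none or still open, it means among the compounds named here.

Compound 3 `Cc1ccccc1-c1nc2c(NC3CCCC3)ncnc2n1C` was tested in a functional assay on CHO cells for antagonist activity at adenosine receptor A2b (Homo sapiens), read by 33P incorporation, with a stated time of 20 min; a lower number here means a stronger inhibitor, a higher number a weaker inhibitor. In this assay compound 3 gives only the limit > 30000 nM, not a number. Compound 1 `Cn1c(-c2ccc(F)cc2)nc2c(NC3CCCC3)ncnc21` gives only the limit > 30000 nM in this assay. Compound 2 `COc1ccc(-c2nc3c(NC4CCCC4)ncnc3n2C)cc1` likewise gives only the limit > 30000 nM in this assay. All three values sit at the limit of > 30000 nM in this assay, at which 3 of the 3 values shown sit, so the steps a step that the two limits leave unreadable from compound 1 to compound 2, a step that the two limits leave unreadable from compound 1 to compound 3 and a step that the two limits leave unreadable from compound 2 to compound 3 cannot be read in size. Compound 4 `Cc1cccc(-c2nc3c(NC4CCCC4)ncnc3n2C)c1` differs from compound 3 in 3-methylphenyl in place of 2-methylphenyl on an aromatic carbon. Within the data shown here, none of the measured steps therefore gives a readable size to lean on, and the only guidance is that compound 3 itself sits at the limit. Compound 4 is expected to stay at or near that limit, with a step that the limit leaves unreadable from compound 3 to compound 4 expected to be no more than the scatter. The estimate for compound 4 in this assay is 40000 nM, with a range from 10000 nM to 150000 nM, and it is expected most likely to come back as a limit again.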

Compound 4, inhibition constant: 6030 nM
Compound 4: the middle estimate sits 6.6-fold (0.82 log units) above what was measured; measured number outside the range, below it.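

In this assay, among these compounds, changing 2-methylphenyl to 3-methylphenyl on this aromatic carbon gives the first change that can be read, an at least 4.9-fold lower number from compound 3 to compound 4 (0.69 log units; beyond the scatter), so where the methyl sits on the phenyl ring matters here, although the atoms stay the same. The steps among compound 1, compound 2 and compound 3 cannot be read, but the same 3-methylphenyl group now also gives an at least 4.9-fold lower number from compound 2 to compound 4 (0.69 log units; beyond the scatter) and an at least 4.9-fold lower number from compound 1 to compound 4 (0.69 log units; beyond the scatter). Each of these steps is a minimum and not a true size, since each starts from a limit and not a number: the limit of > 30000 nM in this assay, at which 3 of the 4 values shown sit.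

On these data alone, the full size of these steps therefore remains unknown. As far as these compounds go, it also remains open whether a methyl is needed at all, or whether an ethyl, a chlorine or an amine in its place on the phenyl ring would lower the number further.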